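The source may hold more compounds than are shown below. What is called first, only, known or untested is meant among the compounds shown, and "the series" means these compounds.

The compounds measured so far:
compound 1, `O=C1c2c[n+]([O-])c3ccccc3c2C(=O)c2c1c1ccccc1n2CCCCN1CCNCC1`, gives 3310 nM in a functional assay on MDA-MB-231 cells (Homo sapiens) for cytotoxicity, read by MTT assay, with a stated time of 72 h; a lower number here means a stronger inhibitor, a higher number a weaker inhibitor
compound 2, `CCCCN1CCN(CCCCn2c3c(c4ccccc42)C(=O)c2c[n+]([O-])c4ccccc4c2C3=O)CC1`, gives 900 nM in this assay
compound 3, `CN(C)CCCCCn1c2c(c3ccccc31)C(=O)c1c[n+]([O-])c3ccccc3c1C2=O`, gives 240 nM in this assay

Compound 3 stands lowest of the three numbers. Its nearest neighbour is compound 2, with a 3.8-fold lower number from compound 2 to compound 3 (0.57 log units; beyond the scatter); compound 1 is furthest away, with a 14-fold lower number from compound 1 to compound 3 (1.14 log units; beyond the scatter). The third measured step, a 3.7-fold lower number from compound 1 to compound 2 (0.57 log units; beyond the scatter), lies between the two larger-numbered compounds.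

Compound 4, `O=C1c2c[n+]([O-])c3ccccc3c2C(=O)c2c1c1ccccc1n2CCCCn1ccnc1`, is the next compound to be measured. Its difference from compound 3 is 1H-imidazol-1-yl in place of (dimethylamino)methyl on a saturated chain carbon, four bonds along the chain from an aromatic nitrogen.

Two measured steps alter the same end of the chain and bear on this change: the large one ending at compound 3, a 14-fold lower number from compound 1 to compound 3 (1.14 log units; beyond the scatter), and the modest one, a 3.8-fold lower number from compound 2 to compound 3 (0.57 log units; beyond the scatter). Within the data shown here, both lead down to compound 3, and no measured compound carries the imidazole group, so nothing shows directly how it behaves. Among the measured compounds shown here, since compound 3 already holds the lowest value, 240 nM, and each variation at this position so far gave a higher number, a modest step upward is expected for compound 4, a 2.9-fold higher number from compound 3 to compound 4 (0.46 log units; beyond the scatter). The estimate for compound 4 is 700 nM, with a range from 200 nM to 2500 nM.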

Compound 4, half-maximal inhibitory concentration: 210 nM
Compound 4: the middle estimate sits 3.3-fold (0.52 log units) above what was measured; the range from low to high includes it.
By their numbers in this assay, from the lowest: compounds 4 and 3 (each within the scatter of the next); then compound 2; then compound 1.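

In this assay the end of this chain accepts an aromatic ring: 1H-imidazol-1-yl in place of (dimethylamino)methyl gives a 1.1-fold lower number from compound 3 to compound 4 (0.06 log units; within the scatter) and so the two groups cannot be told apart here, although one has no ring and the other is a five-membered aromatic ring with 2 hetero atoms. A ring at this place therefore does not by itself bring the higher numbers seen with the two piperazine groups, since the imidazole compound lies clearly lower in both comparisons, with a 4.3-fold lower number from compound 2 to compound 4 (0.63 log units; beyond the scatter) and a 16-fold lower number from compound 1 to compound 4 (1.20 log units; beyond the scatter) as the two steps. No measurement is available that would explain why these groups behave as they do.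

On these data alone, the imidazole appears here on only one chain, so it remains open how a shorter or a longer chain carrying 1H-imidazol-1-yl would compare with compound 4 in this assay. Also open, as far as these compounds go, is how other groups on the same saturated chain carbon would fare, such as a morpholine ring, a 1,2,4-triazole ring or a carboxylic acid.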